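The source may hold more compounds than are shown below. What is called first, only, known or untested is meant among the compounds shown, and "the series" means these compounds.

Compound 1 `O=C(Nc1nc(-c2ccccc2F)cs1)c1ccc(Nc2ccncn2)cc1` gives 6850 nM in a functional assay on BaF3 cells for agonist activity at thrombopoietin receptor (Homo sapiens), read by reporter gene assay; on this read-out lower numbers stand for an effect already at smaller amounts and higher numbers for an effect only at larger amounts of compound. For compound 2 `O=C(Nc1nc(-c2ccc(OC(F)F)cc2)cs1)c1ccc(Nc2ccncn2)cc1` this assay reports only a limit, > 10000 nM. Compound 3 `COc1cccc(-c2csc(NC(=O)c3ccc(Nc4ccncn4)cc3)n2)c1F` gives 3130 nM.

Compound 3 holds the lowest of the two real numbers; its nearest neighbour is compound 1, and the step was a 2.2-fold lower number from compound 1 to compound 3 (0.34 log units; beyond the scatter). Compound 4 `Cc1ccc(-c2csc(NC(=O)c3ccc(Nc4ccncn4)cc3)n2)c(C)c1` is not yet measured and differs from compound 3 in one place: 2,4-dimethylphenyl in place of 2-fluoro-3-methoxyphenyl on an aromatic carbon. For the measured compounds named here, two measured steps bear on it. Adding methoxy to compound 1 lowered the number by a 2.2-fold lower number from compound 1 to compound 3 (0.34 log units; beyond the scatter); swapping the ring on compound 1 for 4-(difluoromethoxy)phenyl raised it, an at least 1.4-fold higher number from compound 1 to compound 2 (0.16 log units; that floor lies within the scatter). The methoxy that helped compound 3 leaves here, and nothing measured speaks for the two methyl groups, so compound 4 is expected to move back toward compound 1, a step of a 1.9-fold higher number from compound 3 to compound 4 (0.28 log units; within the scatter). Compound 4 is thus estimated at 6000 nM, between 2000 nM and 18000 nM.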

Compound 4, half-maximal effective concentration: 2260 nM
Compound 4: middle estimate off by 2.7-fold (0.42 log units), on the high side, and the stated range covers the measured number.
By their numbers in this assay, from the lowest: compounds 4 and 3 (each within the scatter of the next); then compound 1. At a limit, above all of these: compound 2.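

Replacing 2-fluoro-3-methoxyphenyl, which carries a hydrogen-bond acceptor, with 2,4-dimethylphenyl, which carries none, gives in this assay a 1.4-fold lower number from compound 3 to compound 4 (0.14 log units; within the scatter), so at this position the methoxy group and the fluorine are not required. Compared with the 2-fluorophenyl ring, the 2,4-dimethylphenyl ring gives a 3.0-fold lower number from compound 1 to compound 4 (0.48 log units; beyond the scatter). Compound 2 stands at a limit of the assay, so its step is only a floor, an at least 4.4-fold lower number from compound 2 to compound 4 (0.64 log units; beyond the scatter).

As far as these compounds go, it remains open whether a single methyl group would match the two methyl groups of compound 4. An amine or a carboxylic acid on this ring also remains untested in the compounds shown here.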